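A few compounds are considered here, and "the series" means these few. Any claim that something is new, unique, unknown or untested is made for them only; others in the source may bear on it.

Compound 1 `COc1ccc(-c2nnc(SC/C(=N/O)c3ccccc3)n2-c2ccccc2)cc1`, compound 2 `COc1ccc(-c2nnc(SC/C(=N/O)c3ccccc3)n2-c2ccccc2)cc1OC` and compound 3 `CCn1c(SC/C(=N/O)c2ccccc2)nnc1-c1ccc(OC)cc1` were tested in a functional assay on the whole organism (strain albino) for inhibition, with Rattus norvegicus as the target, read by paw edema, with a stated time of 5 h, at a dose of 0.28 mmol/kg by the oral route; on this read-out higher numbers stand for more inhibition at the one dose given (going by the name of the read-out) and lower numbers for less inhibition. In this assay compound 1 gives 73%, compound 2 gives 78% and compound 3 gives 71%. The step of a number 5 percentage points lower from compound 2 to compound 1 (within the scatter) and the step of a number 2 percentage points lower from compound 1 to compound 3 (within the scatter) both fall within the scatter. The difference between the cores of compound 2 and compound 3 is not broken down here.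

Compound 4 `CCn1c(SC/C(=N/O)c2ccccc2)nnc1-c1ccccc1` has not yet been measured. The change from compound 3 to compound 4 is hydrogen in place of methoxy on an aromatic carbon. The same kind of change was made from compound 2 to compound 1, namely (hydrogen in place of methoxy on an aromatic carbon), though the surroundings differ: in compound 2 the methoxy is ortho to a methoxy group and meta to a large group, whereas in compound 3 it is para to a large group. Because the earlier step of a number 5 percentage points lower from compound 2 to compound 1 (within the scatter) was within the scatter, a similarly small step is expected here, a number 4 percentage points lower from compound 3 to compound 4 (within the scatter). Compound 4 is therefore estimated at 67% in this assay, between 57% and 77%.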

Compound 4, a percentage reported as inhibition, in the whole organism at one dose (the size of the read-out at that dose, not a potency): 71%
The estimate for compound 4 lay 4 percentage points below the measured number; the range from low to high includes it.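

In this assay, putting hydrogen in place of methoxy gives no change at the digits printed from compound 3 to compound 4 (within the scatter). Set beside the same change on the other core, the two steps agree: the same change on two cores in this assay, a number 5 percentage points lower (within the scatter) from compound 2 to compound 1 and no change at the digits printed (within the scatter) from compound 3 to compound 4, 5 percentage points apart, within the scatter of two such steps On these two cores, then, the change carries over as one that stays within the usual scatter of this read-out, but this rests on only two pairs of compounds at one dose and does not show that methoxy would be equally dispensable on other cores.

Going by these compounds, what an amine or a carboxylic acid would do in place of methoxy remains open. So does the question of whether a longer chain than ethyl on the aromatic nitrogen would alter the inhibition of paw swelling.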